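Swapping bromo for formyl on the shared core

The compounds below may be only part of what the source reports. "The series", "measured", "known", "first", "only" and "open" are said of these compounds alone.

Measured in a functional assay on HeLa cells (Homo sapiens) for cytotoxicity, with a stated time of 72 h; on this read-out higher numbers stand for weaker inhibition and lower numbers for stronger inhibition:
- compound 1 `COc1ccc(-c2nc3sc(Cc4ccc(Cl)cc4)nn3c2Br)cc1`, 66000 nM
- compound 2 `Clc1ccc(Cc2nn3c(Br)c(-c4ccc(Cl)cc4Cl)nc3s2)cc1`, 118000 nM
- compound 3 `O=[N+]([O-])c1ccc(-c2nc3sc(Cc4ccc(Cl)cc4)nn3c2Br)cc1`, a limit of the assay, > 250000 nM

Compound 1 and compound 2 sit within the scatter of each other, as a 1.8-fold higher number from compound 1 to compound 2 (0.25 log units; within the scatter) shows. The step of an at least 3.7-fold higher number from compound 1 to compound 3 (0.57 log units; beyond the scatter) goes beyond the scatter, and the value of compound 3 is a limit only (the limit of > 250000 nM in this assay, at which 1 of the 3 values shown sits). Compound 4 `COc1ccc(-c2nc3sc(Cc4ccc(Cl)cc4)nn3c2C=O)cc1` differs from compound 1 by formyl in place of bromo on an aromatic carbon. Among the measured compounds shown here, neither measured step touches this position; both alter the aryl group instead, so no measured step bears on the change. The expectation for this assay is therefore no step beyond the scatter, and compound 4 is estimated at 80000 nM, between 25000 nM and 250000 nM, an expected step of a 1.2-fold higher number from compound 1 to compound 4 (0.08 log units; within the scatter).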

Compound 4, half-maximal inhibitory concentration: 6000 nM
Compound 4: middle estimate off by 13-fold (1.12 log units), on the high side; the measured number lies below the stated range.
By their numbers in this assay, from the lowest: compound 4; then compounds 1 and 2 (each within the scatter of the next). At a limit, above all of these: compound 3.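

In this assay, the position carrying bromo on the shared core proves sensitive: formyl in its place gives an 11-fold lower number from compound 1 to compound 4 (1.04 log units; beyond the scatter). Among the compounds shown here, the earlier steps altered only the aryl group, so this is the first sign that the read-out responds to a change at this aromatic carbon. Nothing at hand accounts for the size of this step.

The compounds shown leave open whether the step is particular to formyl or would also appear with a carboxylic acid or an amine at this position. They also leave open whether it would hold with the 2,4-dichlorophenyl group of compound 2.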